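Shortening the Side Chain from Compound 3 to Compound 4

The source may hold more compounds than are shown below. What is called first, only, known or untested is meant among the compounds shown, and "the series" means these compounds.

Of the compounds shown here, three sharing one core have been measured in a functional assay, read by spectrophotometry, with a stated time of 30 min; a lower number here means a stronger inhibitor, a higher number a weaker inhibitor. Compound 1 `CCOC(=O)[C@@H](NC(=O)/C=C/c1ccc(O)c(OC)c1)C(C)C` gives 59600 nM. Compound 2 `CCOC(=O)[C@H](C)NC(=O)/C=C/c1ccc(O)c(O)c1` gives 29700 nM. Compound 3 `CCOC(=O)[C@H](CC(C)C)NC(=O)/C=C/c1ccc(O)c(OC)c1` gives 56100 nM. Among these three numbers compound 3 stands second highest; the step of a 1.1-fold lower number from compound 1 to compound 3 (0.03 log units; within the scatter) lies within the scatter, and the gap from compound 3 to compound 2 also stays within the scatter, so none of the three can be called stronger or weaker than another.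

Compound 4 `CCOC(=O)[C@H](C)NC(=O)/C=C/c1ccc(O)c(OC)c1` has not yet been measured. Going from compound 3 to compound 4 means (hydrogen in place of isopropyl on a saturated chain carbon, two bonds along the chain from an amide-type nitrogen and a carbonyl carbon). For the measured compounds named here, one measured step bears directly on this change: the step of a 1.1-fold lower number from compound 1 to compound 3 (0.03 log units; within the scatter) exchanged one branched chain for another at the same carbon and moved the number no further than the scatter. Compound 2 also carries a hydrogen at this carbon but differs from compound 4 at another place, so its value only shows that a hydrogen there sits comfortably in the same range. Compound 4 is therefore expected to show a step of a 1.2-fold lower number from compound 3 to compound 4 (0.10 log units; within the scatter) that does not go beyond the scatter. For compound 4 the estimated value in this assay is 45000 nM, within a range from 18000 nM to 110000 nM.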

Compound 4, half-maximal inhibitory concentration: 46400 nM
For compound 4 the middle estimate is 1.0-fold (0.01 log units) below the measured one; the range from low to high includes it.
By their numbers in this assay, from the lowest: compounds 2, 4, 3 and 1 (each within the scatter of the next).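

In this assay, the side chain at the saturated chain carbon bound to an amide-type nitrogen and a carbonyl carbon can now be compared from isobutyl to methyl (a 1.2-fold lower number from compound 3 to compound 4 (0.08 log units; within the scatter)) and from isopropyl to methyl (a 1.3-fold lower number from compound 1 to compound 4 (0.11 log units; within the scatter)), and both steps stay within the scatter, so this position tolerates the small methyl as well as the two branched chains. The core also gains its first clean reading of methyl in place of hydrogen on an oxygen on an aromatic ring (a 1.6-fold higher number from compound 2 to compound 4 (0.19 log units; within the scatter)), a change that earlier came only together with a different side chain, and this step also stays within the scatter. Nothing available explains why these changes leave the number inside the scatter.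

Since no step among these compounds goes beyond the scatter, they do not show what at this carbon would move the number at all. On these data alone, it remains open whether an amine, a carboxylic acid or a longer chain there would do so.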